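Piperazine Sulfonamide Replacing Piperidine Sulfone

This account rests on a few compounds, and the source may have more. Where it says the series, first, only, none or still open, it means among the compounds named here.

Measured so far in an assay on isolated protein for inhibition of Nicotinamide phosphoribosyltransferase (Homo sapiens), read by mass spectrometry, with stated times of 15 min and 30 min; on this read-out higher numbers stand for weaker inhibition and lower numbers for stronger inhibition:
compound 1, `O=C(NCc1ccc(S(=O)(=O)c2cncc(C(F)(F)F)c2)cc1)N1Cc2ccncc2C1`: 15 nM
compound 2, `CC(C)n1cc(S(=O)(=O)c2ccc(CNC(=O)N3Cc4ccncc4C3)cc2)cn1`: 20 nM
compound 3, `CN1CCC(S(=O)(=O)c2ccc(CNC(=O)N3Cc4ccncc4C3)cc2)CC1`: 48 nM

Among these three, compound 3 stands at the highest number. The step of a 3.2-fold higher number from compound 1 to compound 3 (0.51 log units; beyond the scatter) and the step of a 2.4-fold higher number from compound 2 to compound 3 (0.38 log units; beyond the scatter) both lie beyond the scatter, while the step of a 1.3-fold higher number from compound 1 to compound 2 (0.12 log units; within the scatter) does not. So the two aromatic groups on the sulfonyl sulfur sit together, and the saturated 1-methylpiperidin-4-yl sits modestly apart from them.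

Compound 4, `CN1CCN(S(=O)(=O)c2ccc(CNC(=O)N3Cc4ccncc4C3)cc2)CC1`, differs from compound 3 in one place: 4-methylpiperazin-1-yl in place of 1-methylpiperidin-4-yl on a sulfonyl sulfur. Within the data shown here, no measured step exchanges one saturated group on the sulfonyl sulfur for another, so the two modest steps into compound 3 give only an indirect guide. Both moved from an aromatic to a saturated ring, whereas here one saturated ring follows another of the same size. Compound 4 is therefore expected to stay near compound 3, with at most a small shift toward a higher number, the expected step being a 1.4-fold higher number from compound 3 to compound 4 (0.13 log units; within the scatter). The estimate for compound 4 in this assay is 65 nM, within a range from 25 nM to 170 nM.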

Compound 4, half-maximal inhibitory concentration: 38 nM
For compound 4 the middle estimate is 1.7-fold (0.23 log units) above the measured one; low and high end bracket the measured number.
By their numbers in this assay, from the lowest: compounds 1, 2, 4 and 3 (each within the scatter of the next, the first and the last beyond it).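

In this assay, among these compounds, the first exchange of one saturated group for another on the sulfonyl sulfur gives a 1.3-fold lower number from compound 3 to compound 4 (0.10 log units; within the scatter) and so puts 4-methylpiperazin-1-yl level with 1-methylpiperidin-4-yl, despite the second ring hetero atom. Set against the aromatic groups, the new ring gives a 1.9-fold higher number from compound 2 to compound 4 (0.28 log units; within the scatter) but a 2.5-fold higher number from compound 1 to compound 4 (0.40 log units; beyond the scatter) and so stands clearly apart only from 5-(trifluoromethyl)pyridin-3-yl, whereas compound 3 stood beyond the scatter from both aromatic groups. Nothing available explains why the two saturated rings read alike.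

The compounds shown leave open what a morpholin-4-yl or an unsubstituted piperazin-1-yl would give on the sulfonyl sulfur. They also leave open whether a longer chain in place of the methyl on the ring nitrogen would stay near compound 3 and compound 4.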